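Chain-end variation on a catechol vinyl sulfone series

A few compounds are considered here, and "the series" means these few. Any claim that something is new, unique, unknown or untested is made for them only; others in the source may bear on it.

Three catechol vinyl sulfones have been run through a functional assay, read by fluorescence and spectrophotometry, with a stated time of 1 h (a higher number here means that more compound is needed for the effect, a lower number that less compound is needed), so far. Compound 1 `CCCCCCCCCCS(=O)(=O)/C=C/c1ccc(O)c(O)c1` gives 6800 nM in this assay, the second highest of the three numbers, but its nearest and furthest neighbours both sit within the scatter. Compound 2 `O=S(=O)(/C=C/c1ccc(O)c(O)c1)CCCCCCCCO` gives 6700 nM in this assay, and compound 3 `C=CCCCCCCCS(=O)(=O)/C=C/c1ccc(O)c(O)c1` gives 6900 nM in this assay. Every measured step is flat: a 1.0-fold lower number from compound 1 to compound 2 (0.01 log units; within the scatter), a 1.0-fold higher number from compound 1 to compound 3 (0.01 log units; within the scatter) and a 1.0-fold higher number from compound 2 to compound 3 (0.01 log units; within the scatter). The three chain ends tried so far therefore cannot be told apart by this assay.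

Compound 4 `O=S(=O)(/C=C/c1ccc(O)c(O)c1)CCCCCCCCCO` has not yet been measured. Relative to compound 1 the change is hydroxy in place of methyl on a saturated chain carbon, nine bonds along the chain from a sulfonyl sulfur. Going by the values given here, the step that bears most directly on it is the one from compound 1 to compound 2, a hydroxy entering a chain carbon one bond closer to the sulfonyl sulfur, and that step was within the scatter; the steps involving compound 3 add that the end of the chain has been tolerant in every case tried. No step beyond the scatter is therefore expected in this assay. Compound 4 is estimated at 6800 nM, within a range of 3400 nM to 13600 nM, which means an expected step of no change at the digits printed from compound 1 to compound 4 (within the scatter).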

Compound 4, half-maximal effective concentration: 7500 nM
For compound 4 the middle estimate is 1.1-fold (0.04 log units) below the measured one; low and high end bracket the measured number.
By their numbers in this assay, from the lowest: compounds 2, 1, 3 and 4 (each within the scatter of the next).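

In this assay, hydroxy in place of methyl on a saturated chain carbon, nine bonds along the chain from a sulfonyl sulfur, gives a step within the scatter (a 1.1-fold higher number from compound 1 to compound 4 (0.04 log units; within the scatter)), so this site accepts the entering hydrogen-bond donor and acceptor with no measurable change. The earlier compounds shown here held hydroxy at only one chain position, whereas hydroxymethyl in place of hydroxy on a saturated chain carbon, eight bonds along the chain from a sulfonyl sulfur (a 1.1-fold higher number from compound 2 to compound 4 (0.05 log units; within the scatter)), shows that extending the hydroxy-bearing chain also leaves the number within the scatter, and 2-hydroxyethyl in place of vinyl on a saturated chain carbon, seven bonds along the chain from a sulfonyl sulfur (a 1.1-fold higher number from compound 3 to compound 4 (0.04 log units; within the scatter)), gives the same reading. No supporting data bear on this flat result.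

On these data alone, whether an amine or a carboxylic acid at the chain end, or a much shorter or longer chain, would give a step beyond the scatter remains open. As far as these compounds go, all four compounds share the core of compound 1, so the effect of changes to that core also remains open.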